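Amide variation on the anilinopyrimidine series

The compounds below may be only part of what the source reports. "The series", "measured", "known", "first", "only" and "open" are said of these compounds alone.

Measured so far:
compound 1 `CN(C)CC(=O)Nc1cccc(Nc2ncc(F)c(Nc3ccc(F)cc3)n2)c1` gives 1260 nM in a functional assay on KB cells (Homo sapiens) for antiproliferative activity, read by sulforhodamine B assay, with a stated time of 3 days; a higher number here means a weaker inhibitor of growth, a lower number a stronger inhibitor of growth
compound 2 `O=C(Nc1cccc(Nc2ncc(F)c(Nc3ccc(F)cc3)n2)c1)c1ccccc1` gives > 10000 nM

The value of compound 2 is a limit of this assay, not a number, as the limit of > 10000 nM in this assay, at which 1 of the 2 values shown sits, records. Compound 2 therefore stands at the weak end of the two measured values. Compound 3 `O=C(Nc1nccs1)c1cccc(Nc2ncc(F)c(Nc3ccc(F)cc3)n2)c1` differs from compound 2 by (1,3-thiazol-2-yl)carbamoyl in place of benzamido on an aromatic carbon. For the measured compounds named here, the only measured step, an at least 7.9-fold higher number from compound 1 to compound 2 (0.89 log units; beyond the scatter), changed the substituent on the carbonyl carbon and does not bear directly on the new change. With compound 2 resting at a limit, no direction for the step can be read from the data. Compound 3 is estimated at 8000 nM (2000 nM to 30000 nM), which means an expected step of an at least 1.2-fold lower number from compound 2 to compound 3 (0.09 log units; that floor lies within the scatter).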

Compound 3, concentration for 50% growth inhibition: > 10000 nM
Compound 3 gave a limit, no number; the forecaster's own chance of this, stated with the estimate: 40%; at least 1.2-fold (0.09 log units) between middle value and limit.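

In this assay compound 3 gives a limit and not a number, and it joins compound 2 there: the limit of > 10000 nM in this assay, at which 2 of the 3 values shown sit.

Replacing benzamido with (1,3-thiazol-2-yl)carbamoyl therefore gives a step that cannot be read. Against the (((dimethylamino)methyl)carbonyl)amino group, the new group gives an at least 7.9-fold higher number from compound 1 to compound 3 (0.89 log units; beyond the scatter), so among the three compounds only compound 1 gives a number.

Any difference between compound 2 and compound 3 beyond the limit remains unknown. From the compounds shown here alone, it also remains open whether the dimethylamino group itself matters, which a longer chain ending in a tertiary amine, or a carboxylic acid in its place, would address.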